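Removing a Bromo Group: Expected Effect on Inhibition

The source may report more compounds than this note shows. Statements on the series, on what has been measured and on what is new or still open speak of the compounds shown alone.

Compound 1 `O=C(Nc1ccc(Sc2nc3ccccc3s2)c(Cl)c1)c1cccc(Br)c1O` is the stronger of the two measured compounds: in an assay for inhibition of HSP60/HSP10 (Homo sapiens), with a stated time of 60 min (a higher number here means a weaker inhibitor, a lower number a stronger inhibitor), compound 1 gives 6900 nM, while compound 2 `O=C(Nc1ccc(Sc2nc3ccccc3s2)cc1)c1cccc(Br)c1O` gives 26000 nM. Going by the values given here, the single measured step, hydrogen in place of chloro on an aromatic carbon, is a 3.8-fold higher number from compound 1 to compound 2 (0.58 log units; beyond the scatter). Compound 3 `O=C(Nc1ccc(Sc2nc3ccccc3s2)c(Cl)c1)c1ccccc1O` differs from compound 1 by hydrogen in place of bromo on an aromatic carbon. Among the compounds with values here, no measured step removes this bromo, so the only guide is that removing a halogen weakened binding modestly. A modest weakening is therefore expected, a 2.2-fold higher number from compound 1 to compound 3 (0.34 log units; beyond the scatter). Compound 3 is expected to give 15000 nM, within a range from 5000 nM to 45000 nM.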

Compound 3, half-maximal inhibitory concentration: > 100000 nM
Compound 3 was reported as a limit (the forecaster's own chance of this, stated with the estimate: 10%); at least 6.6-fold (0.82 log units) between middle value and limit.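

The bromo of the 3-bromo-2-hydroxyphenyl group counts for much more in this assay than the chloro did: its replacement by hydrogen gives an at least 14-fold higher number from compound 1 to compound 3 (1.16 log units; beyond the scatter), a large step, against the modest 3.8-fold higher number from compound 1 to compound 2 (0.58 log units; beyond the scatter). So this position, ortho to a hydroxy group, is one where losing the halogen costs much of the inhibition. Compound 3 stands at a limit, not a number: the limit of > 100000 nM in this assay, at which 1 of the 3 values shown sits.

As far as these compounds go, whether bromo itself is required remains open, since a methyl, methoxy or amine group at this position could hold the inhibition or lose it. From the compounds shown here alone, how much inhibition remains in compound 3 also stays unknown.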